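The compounds below may be only part of what the source reports. "The series", "measured", "known", "first", "only" and "open" are said of these compounds alone.

Measured compounds:
- compound 1, `OC[C@H]1C[C@@H](Cn2cnc3c(O)ncnc32)c2ccccc21`: 24 ug/mL
- compound 2, `CC(C)Nc1ncnc2c1ncn2C[C@@H]1C[C@H](CO)c2ccccc21`: 24 ug/mL
- compound 3, `Cn1ncc2c1[C@@H](CO[Si](c1ccccc1)(c1ccccc1)C(C)(C)C)C[C@H]2Cn1cnc2c(O)ncnc21`: 3.2 ug/mL

In a functional assay on CCRF-CEM cells (Homo sapiens) (on this read-out higher numbers stand for weaker inhibition and lower numbers for stronger inhibition), compound 1 gives 24 ug/mL. Compound 2 stands level with it within the scatter, and together the two hold the highest numbers of the three. Compound 3 lies lower, and the gap from compound 1 to compound 3 is beyond the scatter. Compound 4, `CCCNc1ncnc2c1ncn2C[C@@H]1C[C@H](CO)c2ccccc21`, has not yet been measured. It differs from compound 1 in one place: propylamino in place of hydroxy on an aromatic carbon. Among the compounds with values here, one measured step bears directly on this change, the one in which a hydroxy on the same aromatic carbon was exchanged for an isopropylamino group: no change at the digits printed from compound 1 to compound 2 (within the scatter). That step was flat within the scatter, and propylamino is a close relative of isopropylamino at the same position. The expected step in this assay is therefore none beyond the scatter, no change at the digits printed from compound 1 to compound 4 (within the scatter). For compound 4 the estimated value in this assay is 24 ug/mL, with a range from 12 ug/mL to 48 ug/mL.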

Compound 4, half-maximal inhibitory concentration: 24 ug/mL
Estimate against measurement, compound 4: no gap at the digits printed; measured number inside the range.
By their numbers in this assay, from the lowest: compound 3; then compounds 1, 2 and 4 (each within the scatter of the next).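

In this assay, a second amino group on this aromatic carbon, propylamino in place of hydroxy, gives no change at the digits printed from compound 1 to compound 4 (within the scatter), so the flat result is no longer confined to isopropylamino. The chain on the nitrogen can also be altered, since propyl in place of isopropyl gives no change at the digits printed from compound 2 to compound 4 (within the scatter), and the read-out separates neither chain from the other nor either one from hydroxy. No supporting data are available to account for this flatness.

The compounds shown leave open whether a longer chain such as hexylamino, a ring such as piperidine or a benzylamino group at this carbon would stay level with compound 1. They also leave open whether the same exchange of hydroxy for propylamino would be as flat on the core of compound 3.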